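Replacing 3,5-difluorobenzyl with oxan-4-yl on the amide

The compounds below may be only part of what the source reports. "The series", "measured", "known", "first", "only" and "open" are said of these compounds alone.

Compound 1 `COc1ccc(-c2cc(F)c3ncc(Cc4ccc5ncccc5c4)n3c2)cc1F` gives 407 nM
Compound 2 `O=C(NCC1CCCCN1)c1ccc(-c2cc(F)c3ncc(Cc4ccc5ncccc5c4)n3c2)cc1F` gives 277 nM
Compound 3 `O=C(NCc1cc(F)cc(F)c1)c1ccc(-c2cc(F)c3ncc(Cc4ccc5ncccc5c4)n3c2)cc1F` gives 53.6 nM

In a functional assay on EBC-1 cells (Homo sapiens) for antiproliferative activity, with a stated time of 72 h (a higher number here means a weaker inhibitor, a lower number a stronger inhibitor), compound 3 has the lowest of the three numbers, 53.6 nM. Compound 4 `O=C(NC1CCOCC1)c1ccc(-c2cc(F)c3ncc(Cc4ccc5ncccc5c4)n3c2)cc1F` differs from it by oxan-4-yl in place of 3,5-difluorobenzyl on an amide-type nitrogen. The closest measured parallel is a 5.2-fold lower number from compound 2 to compound 3 (0.71 log units; beyond the scatter), where 3,5-difluorophenyl took the place of piperidin-2-yl. Also relevant are a 7.6-fold lower number from compound 1 to compound 3 (0.88 log units; beyond the scatter) and a 1.5-fold lower number from compound 1 to compound 2 (0.17 log units; within the scatter): only the former lies beyond the scatter. Read in reverse, these steps lead to the expectation of a move of similar size toward a higher number in this assay. The estimated step is a 3.7-fold higher number from compound 3 to compound 4 (0.57 log units; beyond the scatter). For compound 4 the estimate is 200 nM, with an expected range of 80 nM to 500 nM.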

Compound 4, half-maximal inhibitory concentration: 70.5 nM
For compound 4 the middle estimate is 2.8-fold (0.45 log units) above the measured one, and the stated range ends above it.
By their numbers in this assay, from the lowest: compounds 3 and 4 (each within the scatter of the next); then compounds 2 and 1 (each within the scatter of the next).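

In this assay the step of a 1.3-fold higher number from compound 3 to compound 4 (0.12 log units; within the scatter) shows that oxan-4-yl can stand on this amide-type nitrogen in place of 3,5-difluorobenzyl without leaving the scatter, so an aromatic ring of carbon and the two fluorines are not required here. The steps of a 3.9-fold lower number from compound 2 to compound 4 (0.59 log units; beyond the scatter) and a 5.8-fold lower number from compound 1 to compound 4 (0.76 log units; beyond the scatter) both lie beyond the scatter, which separates compound 4 from the other two as compound 3 was already separated. No measurement bears on why these steps arise.
On these data alone, whether a small open chain such as ethyl or a morpholine ring on this nitrogen would stay with compound 3 and compound 4 remains open.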